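Extending an Ester Chain on a Kinase Inhibitor

This account rests on a few compounds, and the source may have more. Where it says the series, first, only, none or still open, it means among the compounds named here.

Compound 2 `COC(=O)c1cccc(-c2cc(C(=O)Nc3ccncc3F)ccc2CN)c1` carries a methyl ester, and in an assay on isolated protein for inhibition of Rho-associated protein kinase 2 (Homo sapiens), read by radiometric assay (a higher number here means a weaker inhibitor, a lower number a stronger inhibitor), compound 2 gives 7.8 nM. That is the lowest of the two numbers recorded so far. Its nearest neighbour is compound 1 `NCc1ccc(C(=O)Nc2ccncc2F)cc1-c1cccc(C(=O)O)c1`, the free acid, which in this assay gives 55 nM; the step of a 7.1-fold lower number from compound 1 to compound 2 (0.85 log units; beyond the scatter) separates the two. Compound 3 `CCCOC(=O)c1cccc(-c2cc(C(=O)Nc3ccncc3F)ccc2CN)c1` is the compound awaiting measurement. Its difference from compound 2 is ethyl in place of hydrogen on a saturated chain carbon bound to an oxygen next to a carbonyl group. Within the data shown here, the only measured step concerns the oxygen next to the carbonyl group, where a hydrogen became a methyl; it says nothing about what lengthening that methyl into a propyl does. Among the measured compounds shown here, no measured step therefore bears directly on this change, and the expected result for the move from compound 2 to compound 3 is a step within the usual scatter, a 1.3-fold higher number from compound 2 to compound 3 (0.11 log units; within the scatter), with no clear direction. Compound 3 is estimated to give 10 nM in this assay, within a range from 4 nM to 30 nM.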

Compound 3, half-maximal inhibitory concentration: 5.1 nM
Beside the measured number, compound 3's estimate is 2.0-fold (0.29 log units) above it; the measured number falls inside the stated range.
By their numbers in this assay, from the lowest: compounds 3 and 2 (each within the scatter of the next); then compound 1.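

Lengthening methoxycarbonyl to propoxycarbonyl gives a 1.5-fold lower number from compound 2 to compound 3 (0.18 log units; within the scatter) in this assay so the two esters cannot be told apart, and this ethyl extension on the saturated chain carbon bound to an oxygen next to a carbonyl group leaves the number where the methyl ester had it. Until now, the only measured ester carried a methyl, so the lower number relative to the free acid could have belonged to that one small group; with propyl in place of hydrogen on the same oxygen, the change gives an 11-fold lower number from compound 1 to compound 3 (1.03 log units; beyond the scatter) and that step lies clearly beyond the scatter, so the difference from the acid is shared by both esters shown. Nothing available here accounts for why either ester differs from the free acid. The compounds shown leave open how far this tolerance for a longer chain extends, for example to a butyl or hexyl chain, to a branched isopropyl or tert-butyl group, or to a benzyl group on the same oxygen. They also leave open whether an amide in place of the ester would keep the number near that of the esters or return it toward that of the acid.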